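Exchanging the Five-Membered Ring on the Carbonyl of Compound 2

The source may report more compounds than this note shows. Statements on the series, on what has been measured and on what is new or still open speak of the compounds shown alone.

Measured so far:
compound 1, `O=C(c1ccccc1F)N1CCCn2nc(COc3ccccc3)cc21`, 62%
compound 2, `O=C(c1ccno1)N1CCCn2nc(COc3ccccc3)cc21`, 22%

Both compounds share one core and differ only in the ring attached to a carbonyl carbon. In a functional assay on HEK293 cells for positive allosteric modulation of metabotropic glutamate receptor 5 (Homo sapiens), read by calcium flux (a lower number here means a smaller maximal response, a higher number a larger maximal response), compound 1 gives 62%, and in this assay compound 2 gives 22%. Among the measured compounds shown here, the one measured step, a number 40 percentage points lower from compound 1 to compound 2 (beyond the scatter), is the whole basis of comparison here. Compound 2 therefore stands at the lower of the two values, separated from compound 1 by a gap beyond the scatter.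

Compound 3, `O=C(c1nccs1)N1CCCn2nc(COc3ccccc3)cc21`, has not yet been measured in this assay. It differs from compound 2 in one place: 1,3-thiazol-2-yl in place of 1,2-oxazol-5-yl on a carbonyl carbon. For the measured compounds named here, no measured step exchanges one five-membered ring for another on this carbonyl carbon; the step of a number 40 percentage points lower from compound 1 to compound 2 (beyond the scatter) replaced 2-fluorophenyl with 1,2-oxazol-5-yl and so bears only loosely on the present change. With nothing closer to lean on, the expected value for compound 3 is near that of compound 2, with room in both directions: an estimated 35%, within 15% to 60%, which amounts to an expected a number 13 percentage points higher from compound 2 to compound 3 (beyond the scatter).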

Compound 3, largest response reached (reported as percent of maximum), in percent of the reference or control that the assay uses: 24%
The estimate for compound 3 lay 11 percentage points above the measured number; measured number inside the range.
By their numbers in this assay, from the lowest: compounds 2 and 3 (each within the scatter of the next); then compound 1.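

In this assay, exchanging one five-membered ring for another on this carbonyl carbon gives a number 2 percentage points higher from compound 2 to compound 3 (within the scatter), so 1,3-thiazol-2-yl and 1,2-oxazol-5-yl cannot be told apart here, even though a sulfur atom in one ring stands in the atom count where the other has an oxygen atom. The change away from 2-fluorophenyl now has a second example, a number 38 percentage points lower from compound 1 to compound 3 (beyond the scatter), so the large gap is not unique to 1,2-oxazol-5-yl and holds for both five-membered rings shown. No measurement at hand accounts for this agreement between the two rings or for their distance from compound 1.

The compounds shown leave open whether the gap follows the change from a six-membered to a five-membered ring or the loss of the fluorine atom, a question that plain phenyl and pyridin-2-yl on the same carbonyl carbon could help to separate. As far as these compounds go, it is also open whether a five-membered ring with a single hetero atom, such as thiophen-2-yl, or a non-aromatic group such as cyclohexyl would behave like these two rings.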